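The source may hold more compounds than are shown below. What is called first, only, known or untested is meant among the compounds shown, and "the series" means these compounds.

In a physicochemical assay for solubility, with a stated time of 3 days, at pH 7 (a lower number here means a less soluble compound, a higher number a more soluble compound), three compounds with a shared core have been measured. Compound 1 `NC(=O)c1ccc2[nH]c(-c3ccc(OCCC4CCCCN4Cc4ccccc4)cc3)nc2c1` gives 155000 nM in this test, and compound 2 `NC(=O)c1ccc2[nH]c(-c3ccc(OCCC4CCCCN4Cc4ccc(Cl)c(Cl)c4)cc3)nc2c1` gives 229000 nM in it. Compound 3 `NC(=O)c1ccc2[nH]c(-c3ccc(OCCC4CCN(Cc5ccccc5)CC4)cc3)nc2c1` gives 5000 nM as the lowest of the three numbers, beyond the scatter from both of the others.

Compound 4 `NC(=O)c1ccc2[nH]c(-c3ccc(OCCC4CCN(Cc5ccc(Cl)cc5)CC4)cc3)nc2c1` is compound 3 with a single change, chloro in place of hydrogen on an aromatic carbon in short, chloro in place of hydrogen on an aromatic carbon, which turns benzyl to 4-chlorobenzyl. Going by the values given here, one measured step bears on this. It is a 1.5-fold higher number from compound 1 to compound 2 (0.17 log units; within the scatter) and lies within the scatter, with 3,4-dichlorophenyl in place of phenyl. That step belongs to compound 1 and compound 2, not to the series of compound 3, so it is only a loose guide. No step beyond the scatter is therefore expected in this assay here. The expected change is a 1.1-fold lower number from compound 3 to compound 4 (0.05 log units; within the scatter) and so stays within the scatter. Compound 4 is expected at 4500 nM in this test, with an estimated range from 1500 nM to 13000 nM around that figure.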

Compound 4, solubility: 2000 nM
Beside the measured number, compound 4's estimate is 2.3-fold (0.35 log units) above it; low and high end bracket the measured number.
By their numbers in this assay, from the lowest: compound 4; then compound 3; then compounds 1 and 2 (each within the scatter of the next).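

In this assay the change to 4-chlorobenzyl gives a 2.5-fold lower number from compound 3 to compound 4 (0.40 log units; beyond the scatter) and so shows that a single chloro at this place, on an aromatic carbon and para to a large group, can move the number modestly beyond the scatter. Going by these compounds alone, the only earlier step of this kind, a 1.5-fold higher number from compound 1 to compound 2 (0.17 log units; within the scatter) with 3,4-dichlorophenyl in place of phenyl, lay within the scatter, but it belongs to a different pair, so the two steps set no pattern. Nothing available here explains the new step.

As far as these compounds go, it remains open whether another group at this place, such as fluoro, methoxy or a nitrile, would move the number as chloro does. From the compounds shown here alone, it also remains open whether chloro alone at this place would do the same on compound 1.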